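Methyl on the saturated ring in a fused pyrimidine series

The compounds below may be only part of what the source reports. "The series", "measured", "known", "first", "only" and "open" are said of these compounds alone.

All values below come from a functional assay on HeLa cells (Homo sapiens) for inhibition, read by MTT assay, with a stated time of 48 h; a higher number here means a weaker inhibitor, a lower number a stronger inhibitor.
Compound 1 `O=C1CN(C2CCCC2)c2nc(Nc3ccc(N4CCCCC4)cn3)ncc2N1` gives a limit, > 30000 nM.
Compound 2 `CC1CCN(c2ccc(Nc3ncc4c(n3)N(C3CCCC3)CC(=O)N4)nc2)CC1` gives a limit, > 30000 nM.
Compound 3 `CCN1C(=O)CN(C2CCCC2)c2nc(Nc3ccc(N4CCCCC4)cn3)ncc21` gives 17600 nM.

Going by the values given here, compound 3 holds the only number; the other two values are limits. The cores of compound 1 and compound 3 differ by ethyl in place of hydrogen on an amide-type nitrogen in a ring, and the step reads an at least 1.7-fold lower number from compound 1 to compound 3 (0.23 log units; that floor lies within the scatter). From compound 1 to compound 2 the change is methyl in place of hydrogen on a saturated ring carbon; the result is a step that the two limits leave unreadable from compound 1 to compound 2 because both values sit at the limit of > 30000 nM in this assay, at which 2 of the 3 values shown sit. Compound 4 `CCN1C(=O)CN(C2CCCC2)c2nc(Nc3ccc(N4CCC(C)CC4)cn3)ncc21` carries the same change on the core of compound 3: methyl in place of hydrogen on a saturated ring carbon. For compound 4 a value near 20000 nM is expected, with a range from 8000 nM to 60000 nM. Among the compounds with values here, the expected step of a 1.1-fold higher number from compound 3 to compound 4 (0.06 log units; within the scatter) rests on compound 3 at 17600 nM and on the one instance of this change seen so far, which reads a step that the two limits leave unreadable from compound 1 to compound 2. For compound 4 a limit is a real possibility.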

Compound 4, half-maximal inhibitory concentration: > 30000 nM
Compound 4: no number, only a limit; the forecaster's own chance of this, stated with the estimate: 40%; middle value at least 1.5-fold (0.17 log units) from the limit.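

In this assay compound 4 gives a limit, > 30000 nM, not a number. On the core of compound 3, methyl in place of hydrogen on a saturated ring carbon reads an at least 1.7-fold higher number from compound 3 to compound 4 (0.23 log units; that floor lies within the scatter), so this change is not shown to separate the two compounds beyond the scatter. Whether the change acts alike on both cores is not shown, and the steps from compound 1 to compound 2 and from compound 2 to compound 4 cannot be read, with both compounds of each pair at the same limit: the limit of > 30000 nM in this assay, at which 3 of the 4 values shown sit.

On these data alone, the true size of the step to compound 4 stays open. Also open, as far as these compounds go, is whether a longer chain than ethyl on the amide-type nitrogen, or an amine in place of methyl on the saturated ring carbon, would give a number in this assay.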